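Series notes: 2-chlorophenyl to 5-chloropyridin-2-yl, compound 4

The compounds below may be only part of what the source reports. "The series", "measured", "known", "first", "only" and "open" are said of these compounds alone.

Three members share one core and differ only in the aromatic group on the five-membered ring: compound 1 `COc1ccc(-c2c(C#N)c(N)nc(SCc3csc(-c4ccc(Cl)c(Cl)c4)n3)c2C#N)cc1`, compound 2 `COc1ccc(-c2c(C#N)c(N)nc(SCc3csc(-c4ccc(Br)cc4)n3)c2C#N)cc1` and compound 3 `COc1ccc(-c2c(C#N)c(N)nc(SCc3csc(-c4ccccc4Cl)n3)c2C#N)cc1`. In an assay on CHO cells for displacement of a labelled ligand from adenosine receptor A1 (Homo sapiens) (on this read-out higher numbers stand for weaker inhibition and lower numbers for stronger inhibition), compound 1 gives 11 nM, compound 2 gives 3.8 nM and compound 3 gives 11 nM. Compound 3 stands level with compound 1 at the digits shown, the two together the highest numbers of the set; against this, a 2.9-fold higher number from compound 2 to compound 3 (0.46 log units; beyond the scatter). Among the other steps, a 2.9-fold lower number from compound 1 to compound 2 (0.46 log units; beyond the scatter), whereas no change at the digits printed from compound 1 to compound 3 (within the scatter).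

Compound 4 `COc1ccc(-c2c(C#N)c(N)nc(SCc3csc(-c4ccc(Cl)cn4)n3)c2C#N)cc1` is the next member. The change is 5-chloropyridin-2-yl in place of 2-chlorophenyl on an aromatic carbon. Among the measured compounds shown here, none of the measured steps bears directly on this exchange: each of them only moves or swaps halogens on a ring of carbon alone, and the largest of them was a 2.9-fold lower number from compound 1 to compound 2 (0.46 log units; beyond the scatter), a modest size. For the measured compounds named here, the change to a ring with one hetero atom has no precedent here, so no direction can be drawn from the data. The expectation for compound 4 is therefore a step of no change at the digits printed from compound 3 to compound 4 (within the scatter), not beyond the scatter, with a wide range to allow for the unprecedented ring. The estimate for compound 4 is 11 nM, within 3.5 nM to 35 nM.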

Compound 4, inhibition constant: 24 nM
Estimate against measurement, compound 4: 2.2-fold (0.34 log units) below; the range from low to high includes it.
By their numbers in this assay, from the lowest: compound 2; then compounds 1 and 3 (each within the scatter of the next); then compound 4.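

In this assay the first ring with a hetero atom at this position, on an aromatic carbon of the five-membered ring, gives a 2.2-fold higher number from compound 3 to compound 4 (0.34 log units; beyond the scatter) and also a 2.2-fold higher number from compound 1 to compound 4 (0.34 log units; beyond the scatter) while the widest gap in the set is a 6.3-fold higher number from compound 2 to compound 4 (0.80 log units; beyond the scatter) and all three steps are modest. Compound 4 therefore stands as the weakest of the four, and among these compounds the only ring with a hetero atom, and the only group with a hydrogen-bond acceptor, carries the highest number, although this rests on a single example. No measurement among the data shown accounts for this shift.

Every pair here changes the halogen pattern along with the ring, so these compounds leave open how much of the step belongs to the ring nitrogen alone. They also leave open how this assay would read for an unsubstituted pyridine ring, a pyrimidine ring or a saturated amine such as morpholine on the same carbon.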